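A few compounds are considered here, and "the series" means these few. Any claim that something is new, unique, unknown or untested is made for them only; others in the source may bear on it.

Measured compounds:
Compound 1, `COc1ccc(NC(=O)c2cn(-c3ccccc3)nc2-c2ccc(C)cc2)cc1`: 1450 nM
Compound 2, `O=C(Nc1ccc(Br)cc1)c1cn(-c2ccccc2)nc1-c1ccc([N+](=O)[O-])cc1`: 4080 nM

Compound 2 has the higher of the two numbers in a functional assay on HCT-116 cells (Homo sapiens) for cytotoxicity, read by MTT assay, with a stated time of 48 h; a lower number here means a stronger inhibitor, a higher number a weaker inhibitor: there compound 1 gives 1450 nM and compound 2 gives 4080 nM, a gap that lies beyond the scatter. Within the data shown here, no step between these two is counted, since compound 1 differs from compound 2 in more than one place. Compound 3, `COc1ccc(NC(=O)c2cn(-c3ccccc3)nc2-c2ccc([N+](=O)[O-])cc2)cc1`, has not been measured. It differs from compound 2 in one place: methoxy in place of bromo on an aromatic carbon. Among the measured compounds shown here, no measured step of this kind is available to anchor the expectation. Compound 1, which also carries the (4-methoxyphenyl)amino part, gives 1450 nM, but its other ring differs too, so it is only a loose guide. The step from compound 2 to compound 3 is expected to be small, toward a lower number, and is estimated at a 1.6-fold lower number from compound 2 to compound 3 (0.21 log units; within the scatter). Compound 3 is expected to give about 2500 nM, within 800 nM to 8000 nM.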

Compound 3, half-maximal inhibitory concentration: 1020 nM
Estimate against measurement, compound 3: 2.5-fold (0.39 log units) above; low and high end bracket the measured number.
By their numbers in this assay, from the lowest: compounds 3 and 1 (each within the scatter of the next); then compound 2.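

Methoxy in place of bromo on an aromatic carbon, para to a large group, gives in this assay a 4.0-fold lower number from compound 2 to compound 3 (0.60 log units; beyond the scatter) and so shows that this position responds to the change with the rest of the structure held constant. Nitro in place of methyl on an aromatic carbon, with methoxy kept, gives a 1.4-fold lower number from compound 1 to compound 3 (0.15 log units; within the scatter) and so separates no effect of that second change in this assay for this pair. No measurement shown explains either step.

The compounds shown compare only bromo and methoxy at this position, so it remains open how an amine, a carboxylic acid or a longer alkoxy chain would read there. Also open, on these data alone, is whether the bromo-to-methoxy step would be the same with methyl in place of nitro on the other ring.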